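Amide variation on the shared core: cytotoxicity notes

The compounds below may be only part of what the source reports. "The series", "measured", "known", "first", "only" and "open" are said of these compounds alone.

Compound 3 `COc1ccc(-c2cnc(NC(=O)c3ccc(C)cc3)n2C)cc1` stands at a limit in a toxicity assay on THP-1 cells (Homo sapiens) for inhibition (on this read-out lower numbers stand for higher toxicity in this test and higher numbers for lower toxicity in this test), and gives > 100000 nM. Compound 1 `COc1ccc(-c2cnc(NC(=O)C3CCNCC3)n2C)cc1` also reaches only a limit in this assay, with > 100000 nM. Compound 2 `COc1ccc(-c2cnc(NC(=O)c3cccc(C#N)c3)n2C)cc1` likewise reports a limit, > 100000 nM. All three values sit at the limit of > 100000 nM in this assay, at which 3 of the 3 values shown sit. The steps a step that the two limits leave unreadable from compound 1 to compound 2, a step that the two limits leave unreadable from compound 1 to compound 3 and a step that the two limits leave unreadable from compound 2 to compound 3 are therefore unreadable, as each rests on two limits. Compound 4 `COc1ccc(-c2cnc(NC(=O)c3cccc(Br)c3)n2C)cc1` differs from compound 3 by 3-bromophenyl in place of 4-methylphenyl on a carbonyl carbon. Within the data shown here, no measured step of readable size bears on this change, so no direction can be drawn from the series. Compound 4 is expected to remain at the limit of this assay, estimated at 100000 nM with a range of 50000 nM to 200000 nM. The step of a number no higher from compound 3 to compound 4 (the limit leaves the size open) is expected to show nothing beyond the scatter.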

Compound 4, half-maximal cytotoxic concentration: > 100000 nM
Compound 4: only a limit was reported; the forecaster's own chance of this, stated with the estimate: 85%; the middle value lies on the limit itself.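

Among these compounds, no step to compound 4 from compound 1, compound 2 or compound 3 can be read, as each rests on two limits: the limit of > 100000 nM in this assay, at which 4 of the 4 values shown sit. The compounds shown leave open whether any amide on the shared core gives a readable value in this assay.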